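This account rests on a few compounds, and the source may have more. Where it says the series, first, only, none or still open, it means among the compounds named here.

Measured compounds:
compound 1 `N/C(=N\NC(=S)N1CCOCC1)c1ccccn1` — 14.7%
compound 2 `N/C(=N\NC(=S)N1CCN(c2ccccn2)CC1)c1ccc(F)cn1` — 13.4%
compound 3 `Cc1ccnc(/C(N)=N/NC(=S)N2CCOCC2)c1` — 1.22%

In a functional assay on MCF7 cells (Homo sapiens) for cytotoxicity, read by MTT assay, with a stated time of 72 h, tested at 1 uM (a lower number here means less inhibition of growth, a higher number more inhibition of growth at the concentration tested), compound 2 stands second highest of the three, within the scatter of compound 1 and beyond the scatter above compound 3. Compound 4 `Cc1ccnc(/C(N)=N/NC(=S)N2CCN(c3ccccn3)CC2)c1` differs from compound 2 by 4-methylpyridin-2-yl in place of 5-fluoropyridin-2-yl on a carbon with a double bond to nitrogen. Within the data shown here, the one measured step that bears on this is the methyl gain on the pyridine ring, where the change went a number 13.5 percentage points lower from compound 1 to compound 3 (beyond the scatter). A fall of similar size is therefore expected for compound 4 in this assay, since the fluorine leaves and a methyl enters. The estimated step is a number 11.4 percentage points lower from compound 2 to compound 4 (beyond the scatter). Compound 4 is expected to reach about 2%, within a range from -6% to 12%.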

Compound 4, percent growth inhibition at one concentration: 21%
Compound 4: the middle estimate sits 19 percentage points below what was measured; the whole stated range lies below it.
By their numbers in this assay, from the lowest: compound 3; then compounds 2, 1 and 4 (each within the scatter of the next).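

In this assay, 4-methylpyridin-2-yl in place of 5-fluoropyridin-2-yl on a carbon with a double bond to nitrogen gives a number 7.6 percentage points higher from compound 2 to compound 4 (within the scatter), so this change shows no clear effect on the core of compound 2. The methyl gain seen as a number 13.5 percentage points lower from compound 1 to compound 3 (beyond the scatter) therefore does not predict this exchange, which also removes fluorine. Nothing available explains the difference between the two results.

Going by these compounds, the separate contributions of the methyl and the fluorine remain open. So does the reading of this assay with an amine or a longer chain on this pyridine ring.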